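Amide substituent variation on the shared core

The compounds below may be only part of what the source reports. "The series", "measured", "known", "first", "only" and "open" are said of these compounds alone.

Of the compounds shown here, three have been measured in an assay on HEK293 cells for positive allosteric modulation of metabotropic glutamate receptor 5 (Homo sapiens), read by FLIPR, with a stated time of 1 h; on this read-out higher numbers stand for an effect only at larger amounts of compound and lower numbers for an effect already at smaller amounts. Compound 1 `O=C1NCCc2nc(C#Cc3cccc(F)c3)sc21` gives 290 nM. Compound 2 `O=C1c2sc(C#Cc3ccccc3)nc2CN1C1CC1` reaches only the limit of the assay, > 10000 nM, and no number stands behind it (the limit of > 10000 nM in this assay, at which 1 of the 3 values shown sits). Compound 3 `CC1CC1C(=O)N1CCc2nc(C#Cc3ccccc3)sc2C1` gives 9.4 nM, the lowest of the two numbers shown; the nearest, compound 1, sits far higher, beyond the scatter. Within the data shown here, no pair of measured compounds differs in only one place, so no single step is known from the measurements.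

Compound 4 `N#Cc1cccc(C(=O)N2CCc3nc(C#Cc4ccccc4)sc3C2)c1` is not yet measured. It differs from compound 3 in one place: 3-cyanophenyl in place of 2-methylcyclopropyl on a carbonyl carbon. Among the measured compounds shown here, the measurements give no step of this kind, so the expectation rests on compound 3 alone, whose value 9.4 nM shows that an amide substituent on the ring nitrogen of the shared core is compatible with a low number. Compound 4 is expected near 25 nM, within 6 nM and 150 nM. Expected is a 2.7-fold higher number from compound 3 to compound 4 (0.42 log units; beyond the scatter), a modest rise that may not go beyond the scatter.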

Compound 4, half-maximal effective concentration: 71 nM
For compound 4 the middle estimate is 2.8-fold (0.45 log units) below the measured one; the range from low to high includes it.
By their numbers in this assay, from the lowest: compound 3; then compound 4; then compound 1. At a limit, above all of these: compound 2.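

In this assay, 3-cyanophenyl in place of 2-methylcyclopropyl on a carbonyl carbon gives a 7.6-fold higher number from compound 3 to compound 4 (0.88 log units; beyond the scatter), the first measured view of how this place responds to a change of group. Compound 4 at 71 nM shows that the place accepts a six-membered aromatic ring carrying a nitrile and is not limited to a three-membered ring, although the 2-methylcyclopropyl amide compound 3 keeps the lower number. Nothing measured here bears on why the number rises with this change.

Open, as far as these compounds go, is whether the higher number of compound 4 follows from the aromatic ring itself or from the nitrile on it, and how an unsubstituted phenyl or a plain cyclopropyl would read on the same carbonyl carbon. From the compounds shown here alone, how a chain ending in an amine or a carboxylic acid would read at this place also remains open.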